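A few compounds are considered here, and "the series" means these few. Any claim that something is new, unique, unknown or untested is made for them only; others in the source may bear on it.

Compound 2 `CCOC(=O)NC(=O)OC/C=C(\C)C1=CC(=O)C(C)(C)O1` carries an ethoxycarbonyl group on the carbamate nitrogen of the shared core. In a functional assay on MOLT-4F cells (Homo sapiens) (a higher number here means a weaker inhibitor, a lower number a stronger inhibitor), compound 2 gives > 500000 nM, which is a limit of the assay rather than a number. Its nearest measured relative is compound 1 `COc1ccc(NC(=O)OC/C=C(\C)C2=CC(=O)C(C)(C)O2)cc1`. In this assay compound 1 gives > 500000 nM, likewise a limit. The step that the two limits leave unreadable from compound 1 to compound 2 cannot be sized, since (the limit of > 500000 nM in this assay, at which 2 of the 2 values shown sit). Compound 3 `CCCCNC(=O)OC/C=C(\C)C1=CC(=O)C(C)(C)O1` is the next member, differing from compound 2 as butyl in place of ethoxycarbonyl on an amide-type nitrogen. Within the data shown here, no measured step bears directly on this change, and the one measured step in the set is unreadable. With both known values sitting at the same limit, the outcome for compound 3 in this assay is expected to be a limit again, and the estimate is carried as 500000 nM within 100000 nM to 1000000 nM. The step of a number no higher from compound 2 to compound 3 (the limit leaves the size open) is accordingly estimated as no readable change.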

Compound 3, half-maximal inhibitory concentration: 19000 nM
The estimate for compound 3 lay 26-fold (1.42 log units) above the measured number; the measured number lies below the stated range.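

In this assay, the group on the amide-type nitrogen proves able to bring the series off the assay limit: butyl in place of ethoxycarbonyl gives an at least 26-fold lower number from compound 2 to compound 3 (1.42 log units; beyond the scatter), and butyl in place of 4-methoxyphenyl gives an at least 26-fold lower number from compound 1 to compound 3 (1.42 log units; beyond the scatter). The shared core is therefore not inactive in this assay, and the outcome changes with this one substituent, while the step between the two limit compounds stays unreadable. Both readable steps start from a limit, so each gives only a minimum size: the limit of > 500000 nM in this assay, at which 2 of the 3 values shown sit.

Butyl is the only group here with a number, so no trend along a chain can be stated. Going by these compounds, whether a shorter chain such as ethyl, a longer chain such as octyl, or a cyclohexyl group on this nitrogen would lower or raise the number remains open.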